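The compounds below may be only part of what the source reports. "The series", "measured", "known", "first", "only" and "open" are said of these compounds alone.

Measured compounds:
- compound 1 `COc1ccc(Nc2nccc(-c3cccs3)n2)cc1`: in a functional assay for inhibition, with Homo sapiens as the target (on this read-out higher numbers stand for weaker inhibition and lower numbers for stronger inhibition), compound 1 gives 3900 nM.
- compound 3 `CN(C)c1ccc(Nc2nccc(-c3cccs3)n2)cc1`: in this assay compound 3 gives 900 nM.
- compound 2 `Cc1cc(-c2ccncc2)nc(Nc2cccc(N(C)C)c2)n1`: in this assay compound 2 gives only a limit, > 24000 nM.

Within the pair sharing one core, the change methoxy in place of dimethylamino on an aromatic carbon gives a 4.3-fold higher number from compound 3 to compound 1 (0.64 log units; beyond the scatter). Compound 2 and compound 3 have different cores; the difference between the two cores is not broken down here.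

Compound 4 `COc1cccc(Nc2nc(C)cc(-c3ccncc3)n2)c1` is not yet measured. It arises from compound 2 by methoxy in place of dimethylamino on an aromatic carbon. This is the same kind of change as that from compound 3 to compound 1, but the place differs: in compound 1 the methoxy sits para to a large group, in compound 4 meta to a large group.

Compound 2 sits at the limit of > 24000 nM in this assay, at which 1 of the 3 values shown sits. Since the same kind of change weakened inhibition in the measured pair, compound 4 is expected to weaken as well or stay near the limit; the expected step is a step that the limit leaves unreadable from compound 2 to compound 4. For compound 4 the estimate in this assay is 60000 nM, between 20000 nM and 200000 nM, most likely reported only as a limit.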

Compound 4, half-maximal inhibitory concentration: > 24000 nM
Compound 4: a limit, no number (the forecaster's own chance of this, stated with the estimate: 85%); the middle value is on the limit's open side.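

In this assay, compound 2 and compound 4 each give only a limit, so the step between them, methoxy in place of dimethylamino, cannot be read: the limit of > 24000 nM in this assay, at which 2 of the 4 values shown sit.

The compounds shown leave open whether this change, meta to a large group on the core of compound 2, shifts inhibition at all, as it does between compound 3 and compound 1.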